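The compounds below may be only part of what the source reports. "The series", "measured", "known", "first", "only" and "open" are said of these compounds alone.

Of the compounds shown here, two that share a core have been tested in a functional assay for activation of Alpha-1B adrenergic receptor (Homo sapiens), read by calcium flux; a lower number here means that less compound is needed, a higher number that more compound is needed for the effect. Compound 1 `CCN(CC)C(=O)c1ccccc1OCC1=NCCN1` returns only a limit in this assay, namely < 5020 nM; for compound 1 nothing more than the limit of < 5020 nM in this assay, at which 1 of the 2 values shown sits, is available, not a number. Compound 2 `c1csc(-c2ccccc2OCC2=NCCN2)c1` gives 3.98 nM in this assay, the only actual number among the two results shown. Compound 3 `Cc1ccc(-c2ccccc2OCC2=NCCN2)s1` differs from compound 2 in a single place: methyl in place of hydrogen on an aromatic carbon. Among the compounds with values here, no step between two measured compounds is available, so these results themselves do not show how such a change moves this assay. The step expected here is a 1.3-fold higher number from compound 2 to compound 3 (0.10 log units; within the scatter), that is, nothing beyond the usual scatter of repeated measurements. Compound 3 is therefore estimated to give 5 nM in this assay, within a range running from 1.5 nM to 20 nM.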

Compound 3, half-maximal effective concentration: < 100000 nM
Compound 3 gave a limit, no number (the forecaster's own chance of this, stated with the estimate: 5%); the middle value does not contradict the limit.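

Within the data shown here, no step from compound 2 to compound 3 can be read, since compound 3 gave only a limit and not a number. The compounds shown leave open whether going from thiophen-2-yl to 5-methylthiophen-2-yl raises, lowers or leaves unchanged the amount of compound needed for the effect.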